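Methanesulfonamido in place of cyano on the shared core

The compounds below may be only part of what the source reports. "The series", "measured", "known", "first", "only" and "open" are said of these compounds alone.

Three measured compounds differ only in one group on an aromatic carbon. In an ADME assay on L6 cells (Rattus norvegicus) for cytotoxicity, read by resazurin assay, with a stated time of 72 h (on this read-out higher numbers stand for weaker inhibition and lower numbers for stronger inhibition), compound 1 `OC(c1ccc(Cl)cc1)(c1ccc(C(F)(F)F)cc1)c1cccnc1` gives 56400 nM. In this assay compound 2 `COc1ccc(C(O)(c2ccc(Cl)cc2)c2cccnc2)cc1` gives 68100 nM.

Compound 3 `N#Cc1ccc(C(O)(c2ccc(Cl)cc2)c2cccnc2)cc1` reads > 100000 nM, which is a limit of the assay and not a number. Compound 3 therefore sits at the limit of > 100000 nM in this assay, at which 1 of the 3 values shown sits.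

Compound 4 `CS(=O)(=O)Nc1ccc(C(O)(c2ccc(Cl)cc2)c2cccnc2)cc1` carries methanesulfonamido in place of cyano on an aromatic carbon, para to a large group (methanesulfonamido in place of cyano on an aromatic carbon). Three measured swaps at this place bear on the change: a 1.2-fold higher number from compound 1 to compound 2 (0.08 log units; within the scatter), an at least 1.7-fold higher number from compound 1 to compound 3 (0.24 log units; that floor lies within the scatter) and an at least 1.4-fold higher number from compound 2 to compound 3 (0.16 log units; that floor lies within the scatter). None is shown beyond the scatter, although the last two are floors only. Among the measured compounds shown here, no measured compound carries methanesulfonamido, so no step beyond the scatter is expected in this assay, and no direction is firmly expected.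

The expected step is an at least 1.2-fold lower number from compound 3 to compound 4 (0.09 log units; that floor lies within the scatter). The estimate for compound 4 is 80000 nM, with an expected range from 40000 nM to 100000 nM.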

Compound 4, half-maximal inhibitory concentration: > 100000 nM
Compound 4: a limit, no number (the forecaster's own chance of this, stated with the estimate: 35%); middle value at least 1.2-fold (0.09 log units) from the limit.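

Compound 4 reads as a limit in this assay, so methanesulfonamido, with its hydrogen-bond donor, joins cyano at this position without giving a number, and the two limits leave the step between compound 3 and compound 4 unreadable. The readable steps are an at least 1.4-fold higher number from compound 2 to compound 4 (0.16 log units; that floor lies within the scatter) and an at least 1.7-fold higher number from compound 1 to compound 4 (0.24 log units; that floor lies within the scatter), so compound 4 is not shown to stand apart from compound 2 or compound 1. Two groups at this position, on an aromatic carbon para to a large group, now end at the same limit: the limit of > 100000 nM in this assay, at which 2 of the 4 values shown sit.

Any order between compound 3 and compound 4 stays open, as does the true size of both steps from the measured compounds. As far as these compounds go, whether an amine or a carboxylic acid at this position would give a number in this read-out, or a step beyond the scatter, also stays open.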